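The source may hold more compounds than are shown below. What is called first, only, known or untested is meant among the compounds shown, and "the series" means these compounds.

Measured compounds in an ADME assay on a cell-free system (plasma, Homo sapiens) for metabolic stability, with Plasma (Rattus norvegicus) as the target, read by HPLC, at pH 7.4; a higher number here means that the compound lasts longer, a lower number that the compound disappears faster:
compound 1 `CC(=O)Oc1ccccc1C(=O)O[C@H]1CO[C@H]2[C@@H]1OC[C@H]2OC(=O)c1snnc1C` gives 0.0642 h
compound 2 `CC(=O)Oc1ccccc1C(=O)O[C@H]1CO[C@H]2[C@@H]1OC[C@H]2OC(=O)c1ccnn1C` gives 0.0963 h
compound 3 `CC(=O)Oc1ccccc1C(=O)O[C@H]1CO[C@H]2[C@@H]1OC[C@H]2OC(=O)c1ccc(C#N)cc1` gives 0.0888 h

All three share the same core and differ only in the acyl group on one ester. The numbers sit close together: a 1.4-fold higher number from compound 1 to compound 3 (0.14 log units; within the scatter) and a 1.5-fold higher number from compound 1 to compound 2 (0.18 log units; within the scatter), so compound 1 is not separated from either neighbour, and a 1.1-fold lower number from compound 2 to compound 3 (0.04 log units; within the scatter) shows the same for the other pair. Across a five-membered ring with three hetero atoms, a five-membered ring with two, and a six-membered carbocycle, this assay returns essentially one value.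

Compound 4 `CC(=O)Oc1ccccc1C(=O)O[C@H]1CO[C@H]2[C@@H]1OC[C@H]2OC(=O)c1cc(C)nc(Cl)c1` is the next step from compound 1. The change is 2-chloro-6-methylpyridin-4-yl in place of 4-methyl-1,2,3-thiadiazol-5-yl on a carbonyl carbon. For the measured compounds named here, the steps that bear on it are those that also swap the acyl ring on compound 1, namely a 1.5-fold higher number from compound 1 to compound 2 (0.18 log units; within the scatter) and a 1.4-fold higher number from compound 1 to compound 3 (0.14 log units; within the scatter); both stay within the scatter. Going by the values given here, a six-membered aromatic ring with one hetero atom has not yet been tried, but nothing among the measured steps points to a move beyond the scatter in this assay in either direction.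

For compound 4 the estimate is therefore 0.09 h, with a range from 0.045 h to 0.18 h. The expected step is a 1.4-fold higher number from compound 1 to compound 4 (0.15 log units; within the scatter).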

Compound 4, half-life: 0.0193 h
Beside the measured number, compound 4's estimate is 4.7-fold (0.67 log units) above it, outside the stated range (below it).
By their numbers in this assay, from the lowest: compound 4; then compounds 1, 3 and 2 (each within the scatter of the next).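

In this assay the acyl group on this carbonyl carbon proves able to move the number after all: 2-chloro-6-methylpyridin-4-yl gives the step (a 3.3-fold lower number from compound 1 to compound 4 (0.52 log units; beyond the scatter)), and the same group set against the other two acyl groups gives (a 4.6-fold lower number from compound 3 to compound 4 (0.66 log units; beyond the scatter)) and (a 5.0-fold lower number from compound 2 to compound 4 (0.70 log units; beyond the scatter)). Compounds 1, 2 and 3 stayed within the scatter of one another and made the acyl ring look interchangeable, whereas compound 4 stands beyond the scatter from all three, on the side of faster disappearance, so the flat picture holds only for those three groups and compound 4 goes against it. Nothing measured alongside these numbers accounts for the step.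

The entering group differs from the others in its ring, its chlorine and its methyl all at once, so the compounds shown do not say which of these carries the step; a plain pyridin-4-yl, or a methoxy group in place of the chlorine, would separate them. Also open, as far as these compounds go, is whether the step holds when the acetyl ester on the other side of the shared core is replaced by an amide.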